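Swapping a Bromine for a Carboxyl Tail on a Phenolic Core

The compounds below may be only part of what the source reports. "The series", "measured", "known", "first", "only" and "open" are said of these compounds alone.

Compound 1, `O=c1c(-c2ccc(O)cc2)coc2cc(OCCCCCCBr)ccc12`, gives 95.7% in a functional assay on mitochondria (Cricetulus griseus) for inhibition of Monoamine oxidase (Homo sapiens), tested at 9 uM; on this read-out higher numbers stand for a stronger effect at the one concentration tested and lower numbers for a weaker effect.
Compound 2, `O=c1c(-c2ccc(O)cc2)coc2cc(OCCCBr)ccc12`, gives 100% in this assay.

Of the two numbers, compound 2 has the larger one, yet the gap to compound 1, a number 4.3 percentage points higher from compound 1 to compound 2 (within the scatter), lies within the scatter, so the two are not truly separated. Compound 3, `O=C(O)CCCCCCCCCOc1ccc2c(=O)c(-c3ccc(O)cc3)coc2c1`, differs from compound 2 by 6-carboxyhexyl in place of bromo on a saturated chain carbon, three bonds along the chain from an oxygen on an aromatic ring. For the measured compounds named here, the single measured step concerns a different change and is within the scatter, so nothing measured bears on the 6-carboxyhexyl group that enters; the expectation rests on compound 2 alone. Compound 3 is expected to give 85%, within 55% to 100%, in this assay. The step of a number 15 percentage points lower from compound 2 to compound 3 (beyond the scatter) is expected to be a modest drop, uncertain in size.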

Compound 3, a percentage reported as inhibition, at one concentration (the size of the read-out at that concentration, not a potency): 95%
Compound 3: the middle estimate sits 10 percentage points below what was measured, and the stated range covers the measured number.
By their numbers in this assay, from the lowest: compounds 3, 1 and 2 (each within the scatter of the next).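

Putting 6-carboxyhexyl in place of bromo on this saturated chain carbon does not separate the compounds in this assay (a number 5 percentage points lower from compound 2 to compound 3 (within the scatter)). The same holds for 3-carboxypropyl in place of bromo, six bonds along the chain from an oxygen on an aromatic ring (a number 0.7 percentage points lower from compound 1 to compound 3 (within the scatter)). So at this position, a carboxyl-ended chain reads the same as either bromo-ended chain, and nothing available explains this.

From the compounds shown here alone, whether an amine or an amide at the chain end would read the same remains open, as does whether a much shorter carboxyl-ended chain would.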